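The compounds below may be only part of what the source reports. "The series", "measured", "known", "first", "only" and "open" are said of these compounds alone.

Measured compounds in a functional assay on A549 cells (Homo sapiens) for antiproliferative activity, read by MTT assay, with a stated time of 48 h; a lower number here means a stronger inhibitor, a higher number a weaker inhibitor:

compound 1 `C/C(=C\CC/C(C)=C/CC[C@@H]1[C@@]2(C)CCC(=O)C(C)(C)[C@H]2CC[C@@]1(C)O)CC/C=C(\C)C(=O)OCc1cn(-c2cccc(O)c2)nn1` gives 42800 nM
compound 2 `C/C(=C\CC/C(C)=C/CC[C@@H]1[C@@]2(C)CCC(=O)C(C)(C)[C@H]2CC[C@@]1(C)O)CC/C=C(\C)C(=O)OCc1cn(-c2cccc(Cl)c2)nn1` gives 147000 nM
compound 3 `C/C(=C\CC/C(C)=C/CC[C@@H]1[C@@]2(C)CCC(=O)C(C)(C)[C@H]2CC[C@@]1(C)O)CC/C=C(\C)C(=O)OCc1cn(C[C@@H]2O[C@H](n3ccc(=O)[nH]c3=O)C[C@H]2O)nn1` gives 28100 nM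

Compound 2 has the highest number of the three; compound 1 stands nearest to it and compound 3 furthest. For the measured compounds named here, the one single-point step recorded is a 3.4-fold higher number from compound 1 to compound 2 (0.54 log units; beyond the scatter). Compound 3 differs from compound 2 in more than one place, so its value shows only that it lies lower.

Compound 4 `C/C(=C\CC/C(C)=C/CC[C@@H]1[C@@]2(C)CCC(=O)C(C)(C)[C@H]2CC[C@@]1(C)O)CC/C=C(\C)C(=O)OCc1cn(-c2ccccc2F)nn1` follows from compound 2 by 2-fluorophenyl in place of 3-chlorophenyl on an aromatic nitrogen. Going by the values given here, no measured step covers an exchange of one halophenyl for another, so the step of a 1.5-fold lower number from compound 2 to compound 4 (0.17 log units; within the scatter) is expected to be small to modest, if anything toward a lower number, since compound 2 already sits at 147000 nM. Compound 4 is thus estimated at 100000 nM, with a range of 40000 nM to 250000 nM.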

Compound 4, half-maximal inhibitory concentration: > 150000 nM
Compound 4: a limit, no number; the forecaster's own chance of this, stated with the estimate: 20%; at least 1.5-fold (0.17 log units) between middle value and limit.
By their numbers in this assay, from the lowest: compounds 3 and 1 (each within the scatter of the next); then compound 2. At a limit, above all of these: compound 4.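

In this assay compound 4 reads > 150000 nM, a limit and not a number. Against the 3-chlorophenyl group the record is an at least 1.0-fold higher number from compound 2 to compound 4 (0.00 log units; that floor lies within the scatter), so this exchange brings no lower number, but its size stays unread. Against the 3-hydroxyphenyl group the record is an at least 3.5-fold higher number from compound 1 to compound 4 (0.54 log units; beyond the scatter), so compound 4, like compound 2, lies on the weaker side of compound 1.

Open, on these data alone, is whether the halogen or its place sets the value, which 3-fluorophenyl would test. Also open, as far as these compounds go, is whether 3-aminophenyl would hold the level of compound 1.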